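From Isobutylcarbonyl to Propargyl on the Ring Nitrogen

A few compounds are considered here, and "the series" means these few. Any claim that something is new, unique, unknown or untested is made for them only; others in the source may bear on it.

Of the compounds shown here, three have so far been tested in an assay on CHO cells for displacement of a labelled ligand from adenosine receptor A1 (Homo sapiens), read by scintillation counting, with a stated time of 1 h, tested at 1 uM; on this read-out lower numbers stand for less inhibition and higher numbers for more inhibition at the one concentration tested (going by the name of the read-out). Compound 1 `Cc1cccc(-c2cnc(N)nc2-c2ccccc2)c1` gives > 80%, which is a limit of the assay rather than a number. Compound 2 `COc1ccc(-c2cnc(N)nc2-c2ccccc2)cc1OC` likewise gives > 80%, again a limit. Within the data shown here, compound 3 `CC(C)CC(=O)Nc1ncc(-c2cccc(Cl)c2)c(-c2ccccc2)n1` gives 56%, the only plain number among the three; the remaining two values are covered by the limit of > 80% in this assay, at which 2 of the 3 values shown sit. No pair of these compounds differs in one place only, so no measured step is available. Compound 4 `C#CCNc1ncc(-c2cccc(Cl)c2)c(-c2ccccc2)n1` is the next candidate, and it differs from compound 3 by propargyl in place of isobutylcarbonyl on a nitrogen on an aromatic ring. Among the measured compounds shown here, with no comparable step to draw on, a moderate rise in this assay is expected, estimated as a number 9 percentage points higher from compound 3 to compound 4 (within the scatter). Compound 4 is therefore expected to show about 65%, within a range from 35% to 90%.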

Compound 4, a percentage reported as inhibition, at one concentration (the size of the read-out at that concentration, not a potency): 76%
Beside the measured number, compound 4's estimate is 11 percentage points below it; the range from low to high includes it.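

In this assay, the nitrogen on the aromatic ring now has a measured step: putting propargyl in place of isobutylcarbonyl gives a number 20 percentage points higher from compound 3 to compound 4 (beyond the scatter). The reading at this position therefore depends on the group placed there, and a group without a carbonyl can read higher than the amide. This single step cannot separate the loss of the carbonyl from the change in chain.

On these data alone, whether a plain methyl, a longer alkyne chain or an amine-bearing chain would read differently on this nitrogen stays open. Any further rise may also no longer appear as a plain number: the limit of > 80% in this assay, at which 2 of the 4 values shown sit.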